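This account rests on a few compounds, and the source may have more. Where it says the series, first, only, none or still open, it means among the compounds named here.

Compound 1 `Cc1cc(C)cc(S(=O)(=O)c2c(C(=O)NCc3ccccc3)[nH]c3ccc(Cl)c(F)c23)c1` is measured in an ADME assay on CCRF-CEM cells (Homo sapiens) for cytotoxicity, read by cell counting (on this read-out lower numbers stand for higher toxicity in this test and higher numbers for lower toxicity in this test), where compound 1 gives 15000 nM. Among the three measured compounds it holds the second highest number. Compound 2 `Cc1cc(C)cc(S(=O)(=O)c2c(C(=O)NCc3ccccc3)[nH]c3ccc([N+](=O)[O-])cc23)c1` gives 8000 nM, within the scatter of compound 1, while compound 3 `Cc1cc(C)cc(S(=O)(=O)c2c(C(=O)NCc3ccccc3)[nH]c3ccc(Cl)cc23)c1` gives 244000 nM, reached by a 16-fold higher number from compound 1 to compound 3 (1.21 log units; beyond the scatter) and, from the nitro analogue, by a 31-fold higher number from compound 2 to compound 3 (1.48 log units; beyond the scatter). Compound 4 `Cc1cc(C)cc(S(=O)(=O)c2c(C(=O)NCN3CCCC3)[nH]c3ccc(Cl)c(F)c23)c1` differs from compound 1 by pyrrolidin-1-yl in place of phenyl on a saturated chain carbon bound to an amide-type nitrogen. Both measured steps alter a group on the shared core, not the part attached to the amide-type nitrogen, so neither bears directly on this change. For the measured compounds named here, with no comparable example, no step beyond the scatter is expected for compound 4: no change at the digits printed from compound 1 to compound 4 (within the scatter). Compound 4 is therefore estimated at 15000 nM, with a range from 4000 nM to 60000 nM.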

Compound 4, half-maximal cytotoxic concentration: 9300 nM
For compound 4 the middle estimate is 1.6-fold (0.21 log units) above the measured one; the range from low to high includes it.
By their numbers in this assay, from the lowest: compounds 2, 4 and 1 (each within the scatter of the next); then compound 3.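

In this assay the change from phenyl to pyrrolidin-1-yl gives a 1.6-fold lower number from compound 1 to compound 4 (0.21 log units; within the scatter) and so stays within the scatter. Unlike the earlier steps, which altered groups on the shared core, this one shows that a non-aromatic ring carrying a nitrogen can stand in place of the all-carbon aromatic ring at this place without a step beyond the scatter. No measured evidence is available to explain this result. From the compounds shown here alone, whether a longer chain, a morpholine ring or a carboxylic acid here would also stay within the scatter remains open. So does whether the same change would give a similar step on the core of compound 3.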